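A few compounds are considered here, and "the series" means these few. Any claim that something is new, unique, unknown or untested is made for them only; others in the source may bear on it.

Measured compounds:
compound 1 `CN(C[C@H]1Cc2c(cccc2N2C[C@@H]3C[C@H]2CN3)CN1)[C@H]1CCCc2cccnc21` gives 36.3%
compound 2 `CN(C[C@H]1Cc2c(cccc2N2CCNCC2)CN1)[C@H]1CCCc2cccnc21` gives 19.9%
compound 3 `CN(C[C@H]1Cc2c(cccc2N2CCN3CCC[C@@H]3C2)CN1)[C@H]1CCCc2cccnc21` gives 36.7%

In an ADME assay on microsomes from liver (Mus musculus) for metabolic stability, read by LC-MS, with a stated time of 10 min (on this read-out higher numbers stand for a more stable compound and lower numbers for a less stable compound), compound 3 carries the highest of the three numbers, yet the step of a number 0.4 percentage points higher from compound 1 to compound 3 (within the scatter) lies within the scatter, so compound 3 and compound 1 cannot be told apart on stability. Among the compounds with values here, only the step of a number 16.8 percentage points higher from compound 2 to compound 3 (beyond the scatter) is a real difference, as is the step of a number 16.4 percentage points lower from compound 1 to compound 2 (beyond the scatter) on the same carbon.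

Compound 4 `CN(C[C@H]1Cc2c(cccc2N2C[C@H]3C[C@@H]2CN3)CN1)[C@H]1CCCc2cccnc21` arises from compound 3 by the change (a group of 7 heavy atoms (5 carbon, 2 nitrogen; 2 five-membered non-aromatic rings with 1 hetero atom each) in place of a group of 9 heavy atoms (7 carbon, 2 nitrogen; one five-membered non-aromatic ring with 1 hetero atom, one six-membered non-aromatic ring with 2 hetero atoms), on an aromatic carbon). Within the data shown here, the group that enters is described in the same terms as the group compound 1 carries, but with its own two defined stereocentres, a form that no measured compound shows. The step that bears most directly on this exchange is a number 0.4 percentage points higher from compound 1 to compound 3 (within the scatter), the same swap taken the other way, and it stayed within the scatter. For compound 4 no change beyond the scatter is therefore expected, the expected step being a number 2.7 percentage points lower from compound 3 to compound 4 (within the scatter). Compound 4 is estimated at 34%, with a range from 20% to 48%.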

Compound 4, percent of the compound remaining: 95.9%
Compound 4: middle estimate off by 61.9 percentage points, on the low side, and the stated range ends below it.
By their numbers in this assay, from the lowest: compound 2; then compounds 1 and 3 (each within the scatter of the next); then compound 4.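

In this assay the step of a number 59.6 percentage points higher from compound 1 to compound 4 (beyond the scatter) shows that, at this aromatic carbon, a group's atoms and bonds do not settle the result, so the two drawn forms of the group cannot be treated as one. The gain can be tied to the drawn stereocentres of the group alone, because nothing else separates this pair: the fact that compounds 1 and 4 differ only in the configuration as drawn. This form of the group also stands clear of the other two groups, with a number 59.2 percentage points higher from compound 3 to compound 4 (beyond the scatter) and a number 76 percentage points higher from compound 2 to compound 4 (beyond the scatter), whereas the form in compound 1 could not be told apart from the group in compound 3.

As far as these compounds go, it stays open whether the other configuration of the group in compound 3 would shift its number as well. From the compounds shown here alone, it is also open whether the high number of compound 4 would hold with a methyl group on the ring nitrogen that carries the hydrogen-bond donor.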